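Replacing the (carboxymethyl)sulfanyl group of compound 2

The compounds below may be only part of what the source reports. "The series", "measured", "known", "first", "only" and "open" are said of these compounds alone.

In a functional assay on the whole organism (strain Hartley) for inhibition, with Cavia porcellus as the target, with stated times of 15 min and 2 min (a lower number here means that less compound is needed, a higher number that more compound is needed for the effect), compound 1 `CCCCC1([C@H](O)/C=C/C2CCC(=O)[C@@H]2CCCCCCC(=O)OCC)CCC1` gives 0.0151 mg/kg, while compound 2 `CCCCC1([C@H](O)/C=C/C2CCC(=O)[C@@H]2CCCCSCC(=O)O)CCC1` gives 0.0912 mg/kg, the higher of the two numbers. Going by the values given here, the only measured step is a 6.0-fold higher number from compound 1 to compound 2 (0.78 log units; beyond the scatter), a modest change beyond the scatter, in which (carboxymethyl)sulfanyl took the place of 2-(ethoxycarbonyl)ethyl. Compound 3 `CCCCC1([C@H](O)/C=C/C2CCC(=O)[C@@H]2CCCCCCCCC(=O)OCC)CCC1` gives up that same group again: 4-(ethoxycarbonyl)butyl in place of (carboxymethyl)sulfanyl on a saturated chain carbon, four bonds along the chain from a saturated ring carbon. The group entering is 4-(ethoxycarbonyl)butyl, on a saturated chain carbon, four bonds along the chain from a saturated ring carbon. Running the measured step backwards would point to a lower number in this assay. However, 4-(ethoxycarbonyl)butyl is not the group compound 1 carries, and no measured compound shows what that difference does. Only part of the measured size is therefore expected, and the expected change is a 2.3-fold lower number from compound 2 to compound 3 (0.36 log units; beyond the scatter). Compound 3 is estimated at 0.04 mg/kg, with an expected range of 0.01 mg/kg to 0.16 mg/kg.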

Compound 3, dose for half-maximal effect: 6.21 mg/kg
Beside the measured number, compound 3's estimate is 160-fold (2.19 log units) below it; the whole stated range lies below it.
By their numbers in this assay, from the lowest: compound 1; then compound 2; then compound 3.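

In this assay, an ethyl ester at the end of the chain does not by itself bring the number down: 4-(ethoxycarbonyl)butyl in place of (carboxymethyl)sulfanyl gives a 68-fold higher number from compound 2 to compound 3 (1.83 log units; beyond the scatter), the opposite direction to the earlier step read backwards. Chain length at this position carries a large effect, since 2-(ethoxycarbonyl)ethyl in place of ethoxycarbonyl, on a saturated chain carbon, six bonds along the chain from a saturated ring carbon, gives a 410-fold higher number from compound 1 to compound 3 (2.61 log units; beyond the scatter). Nothing available explains why the longer ester chain needs so much more compound.

As far as these compounds go, it remains open whether the number climbs gradually or abruptly between these two chain lengths, as a chain ending in 3-(ethoxycarbonyl)propyl might show. Also open, from the compounds shown here alone, is how a free carboxylic acid in place of the ethyl ester would behave on either all-carbon chain.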